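The compounds below may be only part of what the source reports. "The series", "measured", "known", "first", "only" and "open" are said of these compounds alone.

Compound 1 `Cc1cc(CCCOc2c(C)cc(-c3noc(C)n3)cc2C)on1` is the reference point of this small set. In an in vitro ADME assay on microsomes from liver (Simiiformes) (a higher number here means that the compound lasts longer, a lower number that the compound disappears faster), compound 1 gives 0.45 h. Compound 2 `CCc1cc(CCCOc2c(C)cc(-c3noc(C)n3)cc2C)on1` differs from it by methyl in place of hydrogen on a saturated chain carbon bound to an aromatic carbon. In this assay compound 2 gives 0.183 h. That is a 2.5-fold lower number from compound 1 to compound 2 (0.39 log units; beyond the scatter). Compound 3 `Cc1cc(CCCOc2c(C)cc(-c3noc(C(F)F)n3)cc2C)on1` differs from compound 1 by difluoromethyl in place of methyl on an aromatic carbon. In this assay compound 3 gives 1.42 h. That is a 3.2-fold higher number from compound 1 to compound 3 (0.50 log units; beyond the scatter), so compound 3 stands highest of the three measured numbers. For the measured compounds named here, no step is set out between compound 2 and compound 3; their two values simply mark the widest gap in the set.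

Compound 4 `Cc1cc(CCCOc2c(C)cc(-c3noc(C(C)(F)F)n3)cc2C)on1` has not yet been measured in this assay. It differs from compound 3 by methyl in place of hydrogen on a saturated chain carbon bound to an aromatic carbon and two fluorine atoms. Going by the values given here, this is the same kind of change as the one from compound 1 to compound 2, but not the same: there the place was a saturated chain carbon bound to an aromatic carbon, here it is a saturated chain carbon bound to an aromatic carbon and two fluorine atoms, and the two cores differ as described by difluoromethyl in place of methyl on an aromatic carbon. Among the compounds with values here, the only guide to the size of the step is a 2.5-fold lower number from compound 1 to compound 2 (0.39 log units; beyond the scatter). For compound 4 a step of a 1.8-fold lower number from compound 3 to compound 4 (0.25 log units; within the scatter) is expected in this assay, a lowering of similar size rather than a gain, because the earlier step of a 2.5-fold lower number from compound 1 to compound 2 (0.39 log units; beyond the scatter) went down. The estimate for compound 4 in this assay is 0.8 h, with a range from 0.35 h to 2 h, pending measurement.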

Compound 4, half-life: 1.1 h
Compound 4: middle estimate off by 1.4-fold (0.14 log units), on the low side; the measured number falls inside the stated range.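

In this assay, adding the methyl to the difluoromethyl group gives a 1.3-fold lower number from compound 3 to compound 4 (0.11 log units; within the scatter), while 1,1-difluoroethyl in place of the methyl on the aromatic carbon of compound 1 gives a 2.4-fold higher number from compound 1 to compound 4 (0.39 log units; beyond the scatter), so compound 4 keeps a measurable margin over the core of compound 1. Read together, the two methyl steps do not differ beyond the scatter, so the change can be carried between these two cores as far as these values can tell: the same change on two cores in this assay, a 2.5-fold lower number (0.39 log units; beyond the scatter) from compound 1 to compound 2 and a 1.3-fold lower number (0.11 log units; within the scatter) from compound 3 to compound 4, 1.9-fold (0.28 log units) apart, within the scatter of two such steps. For the compounds shown here, this does not fix a common size for the step, since only two pairs are available, one beyond the scatter and one within it, and the added methyl sits at a different place in each; it also says nothing about other cores or about why the numbers move.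

The compounds shown leave open how a trifluoromethyl or a plain ethyl group would compare with 1,1-difluoroethyl on that aromatic carbon. Also open, as far as these compounds go, is whether the higher number of compound 4 over compound 1 would persist when 1,1-difluoroethyl is combined with the change made in compound 2, or with a longer chain in the linker.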